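The source may report more compounds than this note shows. Statements on the series, on what has been measured and on what is new or still open speak of the compounds shown alone.

Measured compounds in the series:

Compound 1 `CC1(C)[C@@H]2CC[C@@]1(CS(=O)(=O)N1CCN(c3cc(C(F)(F)F)ccn3)CC1)C(=O)C2` gives 25100 nM in a functional assay on CHO-K1 cells for antagonist activity at C-X-C chemokine receptor type 3 (Homo sapiens), read by FLIPR and calcium flux; a lower number here means a stronger inhibitor, a higher number a weaker inhibitor.
Compound 2 `CC1(C)[C@@H]2CC[C@@]1(CS(=O)(=O)N1C[C@@H]3C[C@H]1CN3c1ccc(C(F)(F)F)cn1)C(=O)C2` gives only a limit of the assay in this assay, > 31600 nM.
Compound 3 `CC1(C)[C@@H]2CC[C@@]1(CS(=O)(=O)N1CCN(c3ccccn3)CC1)C(=O)C2` likewise gives only a limit of the assay in this assay, > 31600 nM.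

Compound 3 therefore stands at the ceiling of what the assay reports; (the limit of > 31600 nM in this assay, at which 2 of the 3 values shown sit). Among the measured compounds shown here, the one measured step that reaches it, an at least 1.2-fold higher number from compound 1 to compound 3 (0.10 log units; that floor lies within the scatter), removes a trifluoromethyl from the aromatic carbon and is not resolved beyond the scatter. Compound 4 `CC1(C)[C@@H]2CC[C@@]1(CS(=O)(=O)N1CCN(c3ccc(C(F)(F)F)cc3)CC1)C(=O)C2` is not yet measured; it differs from compound 3 by 4-(trifluoromethyl)phenyl in place of pyridin-2-yl on an amine nitrogen in a ring. For the measured compounds named here, no measured step covers an exchange of the ring itself, so the only bearing evidence is the step from compound 1 to compound 3, which was small and ended at a limit. The trifluoromethyl returns in compound 4, and the expectation for this assay is a step of an at least 1.2-fold lower number from compound 3 to compound 4 (0.10 log units; that floor lies within the scatter), that is, no movement beyond the scatter with a fair chance of another limit. Compound 4 is estimated at 25000 nM, within 8000 nM to 60000 nM.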

Compound 4, half-maximal inhibitory concentration: > 31600 nM
Compound 4: only a limit was reported; the forecaster's own chance of this, stated with the estimate: 45%; middle value at least 1.2-fold (0.10 log units) from the limit.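

In this assay the exchange of pyridin-2-yl for 4-(trifluoromethyl)phenyl on the ring amine nitrogen gives no readable result, and the steps that join two limits cannot be read. Among the compounds shown here, the one readable comparison, which replaces 4-(trifluoromethyl)pyridin-2-yl with 4-(trifluoromethyl)phenyl, is an at least 1.2-fold higher number from compound 1 to compound 4 (0.10 log units; that floor lies within the scatter), so losing the ring nitrogen is not resolved. A trifluoromethyl on a carbon-only aromatic ring therefore gives no number in this series, which now sits largely at one edge of the reporting range: the limit of > 31600 nM in this assay, at which 3 of the 4 values shown sit.

Only compound 1 gives a number, 25100 nM, so the contribution of the aromatic group on this nitrogen remains undefined. Open too, from the compounds shown here alone, is whether an amine or a carboxylic acid on that aromatic ring, or a change to the carbonyl of the shared core, would bring values within the measurable range.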